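A few compounds are considered here, and "the series" means these few. Any claim that something is new, unique, unknown or untested is made for them only; others in the source may bear on it.

Measured in a functional assay on HeLa cells (Homo sapiens) for antiproliferative activity, read by sulforhodamine B assay, with a stated time of 48 h; a lower number here means a stronger inhibitor of growth, a higher number a weaker inhibitor of growth:
- Compound 1 `CCCCCc1ccc(-c2cn(CCCN3C(=O)COc4ccccc43)nn2)cc1`: > 100000 nM, a limit
- Compound 2 `O=C1COc2ccccc2N1CCCn1cc(-c2ccccn2)nn1`: 10000 nM
- Compound 3 `O=C1COc2ccccc2N1CCCn1cc(-c2cccnc2)nn1`: > 100000 nM, a limit

Compound 3 has no number, only the limit > 100000 nM. Its place is thus (the limit of > 100000 nM in this assay, at which 2 of the 3 values shown sit). Compound 1 shares that place, so only compound 2 gives a true number in the series.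

Compound 4 `CCCc1cn(CCCN2C(=O)COc3ccccc32)nn1` is the next to be read. It carries propyl in place of pyridin-3-yl on an aromatic carbon. The change removes the six-membered aromatic ring at this place and leaves a chain on the shared core.

Going by the values given here, one measured step bears on it: an at least 10-fold higher number from compound 2 to compound 3 (1.00 log units; beyond the scatter). Among the compounds with values here, that step shows that a change of group at this place can move the number beyond the scatter, but it is a swap between two pyridinyl groups, and no measured compound carries propyl. It therefore gives a poor guide to direction. Only a small step is expected in this assay, and compound 4 may well report a limit too. The estimated step is an at least 1.2-fold lower number from compound 3 to compound 4 (0.09 log units; that floor lies within the scatter).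

For compound 4 the expected value is 80000 nM, with an estimated range from 20000 nM to 300000 nM.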

Compound 4, concentration for 50% growth inhibition: 23200 nM
Beside the measured number, compound 4's estimate is 3.4-fold (0.54 log units) above it; the measured number falls inside the stated range.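

In this assay, going by these compounds alone, the earlier compounds left open whether a measurable number at this aromatic carbon depended on a six-membered aromatic ring, and compound 4 shows that it does not, since propyl, with no ring and no hydrogen-bond acceptor, still gives a true number. Replacing pyridin-3-yl with propyl gives an at least 4.3-fold lower number from compound 3 to compound 4 (0.63 log units; beyond the scatter), and this size is only a floor, since compound 3 reports a limit and not a number. Replacing pyridin-2-yl with propyl gives a 2.3-fold higher number from compound 2 to compound 4 (0.37 log units; beyond the scatter), so among the three compounds with these small groups the order runs from pyridin-2-yl through propyl to pyridin-3-yl, which means that the ring as such does not set the result, though the series can be read only so far: the limit of > 100000 nM in this assay, at which 2 of the 4 values shown sit.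

The compounds shown leave open how a longer chain than propyl, such as butyl, or a branched chain such as isopropyl would compare with compound 4 at this place. They also leave open where pyridin-4-yl or an unsubstituted phenyl would fall relative to compound 2 and compound 3, and whether an amine at the end of the propyl chain would change the number.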